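A few compounds are considered here, and "the series" means these few. Any claim that something is new, unique, unknown or untested is made for them only; others in the source may bear on it.

Measured in a functional assay on HT-29 cells (Homo sapiens) for cytotoxicity, read by MTT assay, with a stated time of 72 h; a higher number here means a weaker inhibitor, a lower number a stronger inhibitor:
- compound 1 `Nc1cccc(Nc2c(C(=O)NCc3ccc(F)cc3)nc(Br)c3cccnc23)c1`: > 10000 nM
- compound 2 `O=C(NCc1ccc(F)cc1)c1nc(Br)c2cccnc2c1N1CCNCC1`: 10000 nM

In this assay compound 1 stands at > 10000 nM, which is a limit of the assay and not a number. The starting point is therefore (the limit of > 10000 nM in this assay, at which 1 of the 2 values shown sits).

The step followed here leads to compound 3 `COC(=O)CNc1c(C(=O)NCc2ccc(F)cc2)nc(Br)c2cccnc12`, which carries (methoxycarbonyl)methyl in place of 3-aminophenyl on a nitrogen on an aromatic ring. Cut one bond further out, this is (3-aminophenyl)amino to ((methoxycarbonyl)methyl)amino.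

Within the data shown here, one measured step bears on this: a number no higher from compound 1 to compound 2 (the limit leaves the size open), with piperazin-1-yl in place of (3-aminophenyl)amino on an aromatic carbon. Among the measured compounds shown here, its size cannot be read, and compound 2 at 10000 nM offers the only actual number. With no measured size to carry over, no step beyond the scatter is expected in this assay, in either direction, and another reading at the limit is quite likely.

The expected step is a number no higher from compound 1 to compound 3 (the limit leaves the size open). For compound 3 the estimated value is 10000 nM, with an expected range of 4000 nM to 25000 nM.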

Compound 3, half-maximal inhibitory concentration: > 10000 nM
Compound 3: only a limit was reported; the forecaster's own chance of this, stated with the estimate: 65%; the middle value lies on the limit itself.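

In this assay compound 3 gives > 10000 nM, which is a limit of the assay and not a number. With ((methoxycarbonyl)methyl)amino in place of piperazin-1-yl on an aromatic carbon, the data show a number no lower from compound 2 to compound 3 (the limit leaves the size open). The step from compound 1 to compound 3 cannot be read, so the change from 3-aminophenyl to (methoxycarbonyl)methyl on this nitrogen has no measurable size. What compound 3 adds is that this nitrogen has now carried both a six-membered aromatic ring and a group with no ring, and the reading stayed at the limit with each, so the series gives no sign yet of a difference between them: the limit of > 10000 nM in this assay, at which 2 of the 3 values shown sit.

Among these compounds, compound 2, at 10000 nM, remains the only compound with an actual number, and that reading comes from a change at the aromatic carbon rather than a different group on this nitrogen. As far as these compounds go, whether a carboxylic acid in place of (methoxycarbonyl)methyl, or a longer chain ending in an amine, would bring a readable number in this assay remains open.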